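Removing the methyl from compound 3

The compounds below may be only part of what the source reports. "The series", "measured", "known", "first", "only" and "open" are said of these compounds alone.

Of the compounds shown here, three have been measured in a functional assay on HeLa cells (Homo sapiens) for cytotoxicity, read by MTT assay, with a stated time of 72 h; a higher number here means a weaker inhibitor, a lower number a stronger inhibitor. Compound 1 `N/C(=N\NC(=S)N1CCOCC1)c1ccccn1` gives 7300 nM, compound 2 `Cc1cccc(/C(N)=N/NC(=S)N2CCSCC2)n1` gives 1800 nM, and compound 3 `Cc1ccnc(/C(N)=N/NC(=S)N2CCSCC2)c1` gives 15500 nM. Compound 3 stands at the highest number of the three: compound 1 lies nearest, at a lower number, a gap beyond the scatter, and compound 2 lies furthest, at a still lower number, also beyond the scatter.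

Compound 4 `N/C(=N\NC(=S)N1CCSCC1)c1ccccn1` has not yet been measured in this assay. It differs from compound 3 by hydrogen in place of methyl on an aromatic carbon, so the methyl is gone and the rest of the molecule is kept. Among the measured compounds shown here, no measured pair shows this exact change, so its size is open. Compound 1 shares the unsubstituted core of compound 4 and gives a lower number than compound 3, while compound 2 shows that where the methyl sits matters strongly. Compound 4 is therefore expected to give a lower number, with an estimated step of a 3.1-fold lower number from compound 3 to compound 4 (0.49 log units; beyond the scatter) that is probably beyond the scatter. Compound 4 is estimated at 5000 nM, within a range from 1500 nM to 15000 nM.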

Compound 4, half-maximal inhibitory concentration: 7800 nM
For compound 4 the middle estimate is 1.6-fold (0.19 log units) below the measured one; measured number inside the range.
By their numbers in this assay, from the lowest: compound 2; then compounds 1, 4 and 3 (each within the scatter of the next, the first and the last beyond it).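

In this assay, hydrogen in place of methyl on the aromatic carbon opposite the ring nitrogen gives a step within the scatter (a 2.0-fold lower number from compound 3 to compound 4 (0.30 log units; within the scatter)), so the methyl at this place has no clear effect on the number. Hydrogen in place of the methyl of compound 2, which stands elsewhere on the ring, gives a step beyond the scatter (a 4.3-fold higher number from compound 2 to compound 4 (0.64 log units; beyond the scatter)), so only the methyl at that other place is tied to a clear difference. Thiomorpholin-4-yl in place of morpholin-4-yl on the thiocarbonyl carbon also stays within the scatter (a 1.1-fold higher number from compound 1 to compound 4 (0.03 log units; within the scatter)).

The compounds shown leave open how an ethyl, a methoxy or an amine would behave at the carbon opposite the ring nitrogen. Nothing available explains the difference between the two methyl places.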